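This account rests on a few compounds, and the source may have more. Where it says the series, first, only, none or still open, it means among the compounds named here.

Working notes on the series. Compound 1 `COc1ccc(Cn2nc(-c3ccccc3)c3cc(C(=N)Nc4ccccc4)ncc32)cc1` gives 4700 nM in a functional assay on HT-1080 cells (Homo sapiens) for cytotoxicity, read by MTT assay, with a stated time of 72 h; on this read-out higher numbers stand for weaker inhibition and lower numbers for stronger inhibition. Compound 3 `COc1ccc(Cn2nc(-c3ccccc3)c3cc(C(=N)Nc4cccc(C(F)(F)F)c4)ncc32)cc1` carries trifluoromethyl in place of hydrogen on an aromatic carbon and gives 46700 nM in this assay; the step is a 9.9-fold higher number from compound 1 to compound 3 (1.00 log units; beyond the scatter). Compound 2 `N=C(Nc1ccccc1)c1cc2cn[nH]c2cn1` gives "not determined" (no result reported) in this assay, so no result is reported for it; the difference between its core and that of compound 1 is not broken down here. Compound 4 `N=C(Nc1cccc(C(F)(F)F)c1)c1cc2cn[nH]c2cn1` stands to compound 2 as compound 3 stands to compound 1, carrying (trifluoromethyl in place of hydrogen on an aromatic carbon), the same change at the same kind of place. For compound 4, the step from compound 2 is expected to be of a size comparable to the earlier one, since it rests only on the step seen from compound 1 to compound 3 and no number for compound 2 exists. Compound 4 is estimated at 100000 nM in this assay, within a broad range from 15000 nM to 600000 nM.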

Compound 4, half-maximal inhibitory concentration: 36500 nM
Beside the measured number, compound 4's estimate is 2.7-fold (0.44 log units) above it, within the range that was stated.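

For the compounds shown here, no step from compound 2 to compound 4 can be read from the values shown. As far as these compounds go, whether trifluoromethyl in place of hydrogen gives a step on the core of compound 2 comparable to the one on the core of compound 1 stays open. Nothing shown offers an explanation for these values.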